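A few compounds are considered here, and "the series" means these few. Any claim that something is new, unique, unknown or untested is made for them only; others in the source may bear on it.

Working notes on the side chain of the series. In a physicochemical assay for solubility, read by spectrophotometry, in phosphate buffer, with a stated time of 2 h, at pH 7.4 (on this read-out higher numbers stand for higher solubility and lower numbers for lower solubility), compound 1 `COc1ccc2[nH]c(C(=O)N3CC(=O)N(Cc4ccccc4)[C@@H](CCc4ccccc4)C3)cc2c1` gives 4400 nM, compound 2 `COc1ccc2[nH]c(C(=O)N3CC(=O)N(Cc4ccccc4)[C@@H](COc4ccccc4)C3)cc2c1` gives 12200 nM and compound 3 `COc1ccc2[nH]c(C(=O)N3CC(=O)N(Cc4ccccc4)[C@@H](CN4CC5CC5C4)C3)cc2c1` gives 17500 nM. Compound 3 shares the upper end of these numbers with compound 2: a 1.4-fold higher number from compound 2 to compound 3 (0.16 log units; within the scatter) is within the scatter, while a 4.0-fold higher number from compound 1 to compound 3 (0.60 log units; beyond the scatter) is beyond it, as is a 2.8-fold higher number from compound 1 to compound 2 (0.44 log units; beyond the scatter).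

The next compound is compound 4 `COc1ccc2[nH]c(C(=O)N3CC(=O)N(Cc4ccccc4)[C@@H](CN4CCC5(CCCC5)CC4)C3)cc2c1`, and the change is a group of 10 heavy atoms (9 carbon, 1 nitrogen; one five-membered non-aromatic ring of carbon only, one six-membered non-aromatic ring with 1 hetero atom) in place of a group of 6 heavy atoms (5 carbon, 1 nitrogen; one three-membered non-aromatic ring of carbon only, one five-membered non-aromatic ring with 1 hetero atom), on a saturated chain carbon bound to a saturated ring carbon. For the measured compounds named here, no measured step shows a group growing in this way, so the evidence is indirect. Going by the values given here, the steps that bear on it are the two beyond the scatter, both modest, and each starts from the all-carbon group of compound 1 at 4400 nM. The entering group keeps one nitrogen but carries more carbon than the group it replaces, so a modest move to lower numbers in this assay is expected, stopping short of a full return to the value of compound 1. The expected size of the change is a 2.3-fold lower number from compound 3 to compound 4 (0.37 log units; beyond the scatter). For compound 4 the estimated value is 7500 nM, with an expected range from 2800 nM to 17000 nM.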

Compound 4, solubility: 5000 nM
For compound 4 the middle estimate is 1.5-fold (0.18 log units) above the measured one; the measured number falls inside the stated range.
By their numbers in this assay, from the lowest: compounds 1 and 4 (each within the scatter of the next); then compounds 2 and 3 (each within the scatter of the next).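

In this assay, a larger group that keeps one nitrogen, on a saturated chain carbon bound to a saturated ring carbon, gives a 3.5-fold lower number from compound 3 to compound 4 (0.54 log units; beyond the scatter), the only step shown in which one nitrogen-bearing group replaces another. The same entering group gives a 2.4-fold lower number from compound 2 to compound 4 (0.39 log units; beyond the scatter) and also a 1.1-fold higher number from compound 1 to compound 4 (0.06 log units; within the scatter), so the presence of a nitrogen in the group does not by itself separate a side chain from the all-carbon group of compound 1 on this read-out. No measurement available here bears on the reason for these steps.

Compound 3 and compound 4 differ at once in heavy-atom count and in their ring systems, so the compounds shown cannot say whether the size of the group or the kind of ring accounts for the step between them. Going by these compounds, how a plain piperidine, or a morpholine with an oxygen in its ring, would stand at this place remains open, and either would help separate those two readings.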